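A few compounds are considered here, and "the series" means these few. Any claim that something is new, unique, unknown or untested is made for them only; others in the source may bear on it.

In a functional assay on HeLa cells (Homo sapiens) for inhibition (a lower number here means a stronger inhibitor, a higher number a weaker inhibitor), compound 1 `Nc1nc(O)c2ncn(/C=C/C=O)c2n1` is reported only as a limit, > 100000 nM. Compound 2 `O=C/C=C/n1ccc(=O)[nH]c1=O` gives 30000 nM. Among the measured compounds shown here, compound 3 `O=C/C=C/n1cc(F)c(=O)[nH]c1=O` gives 60000 nM, which places it within the scatter of compound 2, the only other compound here with a measured number.

Compound 4 `O=C/C=C/n1cc(CO)c(=O)[nH]c1=O` departs from compound 3 in a single group: hydroxymethyl in place of fluoro on an aromatic carbon. This places hydroxymethyl in place of fluoro on an aromatic carbon, meta to a 2-formylethenyl group.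

For the measured compounds named here, one measured step bears on this carbon: a 2.0-fold higher number from compound 2 to compound 3 (0.30 log units; within the scatter), where fluoro replaced hydrogen. That exchange left the two numbers within the scatter of each other. Going by the values given here, no measured compound carries hydroxymethyl, however, so this single step is thin support for a forecast. Starting from compound 3 at 60000 nM, and given the small step of a 2.0-fold higher number from compound 2 to compound 3 (0.30 log units; within the scatter), no change beyond the scatter is expected in this assay, and no clear direction can be assigned.

For compound 4 the estimated value is 50000 nM, with an expected range from 20000 nM to 100000 nM. Expressed as a change, the estimate means a 1.2-fold lower number from compound 3 to compound 4 (0.08 log units; within the scatter).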

Compound 4, half-maximal inhibitory concentration: > 100000 nM
Compound 4: only a limit was reported; the forecaster's own chance of this, stated with the estimate: 15%; middle value at least 2.0-fold (0.30 log units) away from the limit.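

In this assay compound 4 is reported as > 100000 nM, which is a limit of the assay and not a measured number: the limit of > 100000 nM in this assay, at which 2 of the 4 values shown sit. Set against the fluoro compound, the exchange of fluoro for hydroxymethyl gives an at least 1.6-fold higher number from compound 3 to compound 4 (0.22 log units; that floor lies within the scatter), so this comparison alone does not separate the two groups. Set against the compound with hydrogen on this aromatic carbon, hydroxymethyl gives an at least 3.3-fold higher number from compound 2 to compound 4 (0.52 log units; beyond the scatter), and this is the first step at this carbon to pass beyond the scatter, since a 2.0-fold higher number from compound 2 to compound 3 (0.30 log units; within the scatter) did not, showing that the number in this assay can respond to the group placed here, with hydroxymethyl moving it towards weaker inhibition.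

Since compound 4 sits at a limit, the compounds shown leave open how large the step to hydroxymethyl really is, and whether fluoro and hydroxymethyl truly differ at this carbon. They also leave open whether a methyl, an amine, a carboxylic acid or a longer chain ending in a hydroxyl on this same carbon would give a measurable number, and on which side of hydrogen it would fall.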